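The compounds below may be only part of what the source reports. "The series", "measured", "known", "first", "only" and "open" are said of these compounds alone.

Three compounds share one core and differ only in the aryl group on the saturated chain carbon bound to the amide-type nitrogen. Compound 1 `O=C(O)C[C@@H](NC(=O)[C@@H]1CCN1S(=O)(=O)c1cc(Cl)cc(Cl)c1)c1ccc(OC2CCCC2)cc1` gives 0.5 nM in an assay on RPMI-8866 cells for inhibition of integrin alpha-4/beta-1 (Homo sapiens); a higher number here means a weaker inhibitor, a lower number a stronger inhibitor. Compound 2 `O=C(O)C[C@@H](NC(=O)[C@@H]1CCN1S(=O)(=O)c1cc(Cl)cc(Cl)c1)c1ccc(OC(F)F)cc1` gives 1.3 nM in this assay, and compound 3 `O=C(O)C[C@@H](NC(=O)[C@@H]1CCN1S(=O)(=O)c1cc(Cl)cc(Cl)c1)c1ccc(Cl)c(F)c1` gives 11 nM in this assay. Among these three numbers compound 2 stands second highest: a 2.6-fold higher number from compound 1 to compound 2 (0.41 log units; beyond the scatter), and an 8.5-fold higher number from compound 2 to compound 3 (0.93 log units; beyond the scatter).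

Compound 4 `O=C(O)C[C@@H](NC(=O)[C@@H]1CCN1S(=O)(=O)c1cc(Cl)cc(Cl)c1)c1ccc(OCC(F)(F)F)cc1` has not yet been measured. It differs from compound 2 by 2,2,2-trifluoroethyl in place of difluoromethyl on an oxygen on an aromatic ring. Among the measured compounds shown here, of the measured steps, only the one from compound 1 to compound 2 alters the group on that oxygen, and it was modest in size, a 2.6-fold higher number from compound 1 to compound 2 (0.41 log units; beyond the scatter). The step to compound 3 exchanges the whole aryl group and bears less directly. Compound 4 is therefore expected to land close to compound 2, with at most a modest step in either direction, estimated as a 1.3-fold lower number from compound 2 to compound 4 (0.11 log units; within the scatter). The value expected for compound 4 in this assay is 1 nM, within a range from 0.4 nM to 2.5 nM.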

Compound 4, half-maximal inhibitory concentration: 1.4 nM
Beside the measured number, compound 4's estimate is 1.4-fold (0.15 log units) below it; the measured number falls inside the stated range.
By their numbers in this assay, from the lowest: compound 1; then compounds 2 and 4 (each within the scatter of the next); then compound 3.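

In this assay, placing 2,2,2-trifluoroethyl instead of difluoromethyl on the oxygen on the aromatic ring gives a 1.1-fold higher number from compound 2 to compound 4 (0.03 log units; within the scatter), so at this position the two fluorinated groups cannot be told apart, even though they differ in chain size and fluorine count. The cyclopentyl group of compound 1 remains separated from the new group, with a 2.8-fold higher number from compound 1 to compound 4 (0.45 log units; beyond the scatter), and this gap is beyond the scatter, as is the one already seen for difluoromethyl. No measurement is available that would explain either result.

Going by these compounds, it remains open whether groups without fluorine on that oxygen, such as methyl or ethyl, would match compounds 2 and 4. Also open, on these data alone, is where a longer chain such as trifluoropropyl, or a smaller ring such as cyclopropyl, would fall relative to compound 1.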